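Ring Methyl Added to the Dimethylamide Analogue

The compounds below may be only part of what the source reports. "The series", "measured", "known", "first", "only" and "open" are said of these compounds alone.

Three compounds of the series carry a measurement in an assay on the whole organism (plasma, strain Sprague-Dawley) for inhibition of Dipeptidyl peptidase 4 (Rattus norvegicus), with a stated time of 6 h, at a dose of 1 mg/kg by the oral route; a higher number here means more inhibition at the dose given (going by the name of the read-out), a lower number less inhibition. Compound 1 `C[C@@H]1N[C@H](C(=O)N2CCC[C@H]2C#N)C[C@@H]1C(=O)N1CCC1` gives 94%, and compound 2 `C[C@@H]1N[C@H](C(=O)N2CCC[C@H]2C#N)C[C@@H]1C(=O)N1CCOCC1` gives 94%. The step of no change at the digits printed from compound 1 to compound 2 (within the scatter) shows that swapping the amide ring leaves the read-out where it was. Compound 3 `CN(C)C(=O)[C@@H]1CN[C@H](C(=O)N2CCC[C@H]2C#N)C1` gives 76%, the lowest of the three numbers and beyond the scatter from both compound 1 and compound 2.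

Compound 4 `C[C@@H]1N[C@H](C(=O)N2CCC[C@H]2C#N)C[C@@H]1C(=O)N(C)C` differs from compound 3 by methyl in place of hydrogen on a saturated ring carbon. For the measured compounds named here, no measured step isolates this change: compound 1 and compound 2 both carry the methyl but also a different amide ring, so each differs from compound 3 in two places. What the numbers do show is that both methyl-bearing compounds sit above compound 3 by the same margin, while the amide ring swap between them changes nothing. Going by the values given here, the rise is therefore provisionally assigned to the methyl, with the caution that only two compounds support it.

On this basis a gain beyond the scatter is expected, with a number 13 percentage points higher from compound 3 to compound 4 (beyond the scatter) as the estimated step. Compound 4 is expected to give 89%, within 74% to 97%.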

Compound 4, a percentage reported as inhibition, in the whole organism at one dose (the size of the read-out at that dose, not a potency): 95%
Beside the measured number, compound 4's estimate is 6 percentage points below it; the range from low to high includes it.
By their numbers in this assay, from the lowest: compound 3; then compounds 1, 2 and 4 (each within the scatter of the next).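

In this assay the methyl in place of hydrogen on a saturated ring carbon, next to the ring nitrogen, can now be read as a single change with the dimethylcarbamoyl group held fixed, and it gives a number 19 percentage points higher from compound 3 to compound 4 (beyond the scatter) on this core. With the methyl present, the group on the carbonyl carbon can be exchanged with no step beyond the scatter: dimethylamino in place of morpholin-4-yl gives a number 1 percentage points higher from compound 2 to compound 4 (within the scatter) and dimethylamino in place of azetidin-1-yl gives a number 1 percentage points higher from compound 1 to compound 4 (within the scatter) in the same read-out, so these three amide groups are not told apart at this dose and time. The data at hand offer nothing that accounts for the rise seen with the methyl.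

Going by these compounds, whether an ethyl group, a longer chain or a hydroxymethyl group on the same ring carbon would hold the number reached with the methyl remains open. Also open, on these data alone, is how a carboxylic acid or a primary amide in place of the tertiary amides would read with the methyl present, and whether compound 1, compound 2 and compound 4 would separate at a lower dose or a later time.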